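A longer chain on compound 3

The source may report more compounds than this note shows. Statements on the series, on what has been measured and on what is new or still open speak of the compounds shown alone.

Values so far in a functional assay on SW480 cells (Homo sapiens) for antiproliferative activity, read by MTT assay, with a stated time of 48 h (a higher number here means a weaker inhibitor, a lower number a stronger inhibitor), for each compound
compound 1 `CCCCC(CCO)n1cnc2c(Cl)nc(Cl)nc21` gives 30900 nM
compound 2 `CCCCCC(CCO)n1cnc2c(Cl)ncnc21` gives > 50000 nM as a limit
compound 3 `C=C(CO)C(CCCCC)n1cnc2c(Cl)ncnc21` gives > 50000 nM as a limit

For compound 3 the value > 50000 nM in this assay is a limit and not a number. It sits with compound 2 at the limit of > 50000 nM in this assay, at which 2 of the 3 values shown sit, and so cannot be ranked against it. Compound 4 `C=C(CO)C(CCCCCCCCC)n1cnc2c(Cl)ncnc21` differs from compound 3 by one change (butyl in place of hydrogen on a saturated chain carbon, six bonds along the chain from an aromatic nitrogen and a double-bonded chain carbon). For the measured compounds named here, the one measured step here is a step that the two limits leave unreadable from compound 2 to compound 3 and it concerns a different change, so it gives no size to carry over. Going by the values given here, compound 1 gives the only number at 30900 nM but no measured step links it to compound 4. A modest shift toward stronger inhibition in this assay is therefore expected, only loosely grounded, and compound 4 may well stay at the limit. The estimated step runs an at least 2.0-fold lower number from compound 3 to compound 4 (0.30 log units; that floor lies within the scatter) and starts from a limit. For compound 4 the estimated value is 25000 nM with an expected range from 8000 nM to 50000 nM in this assay.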

Compound 4, half-maximal inhibitory concentration: 27600 nM
Beside the measured number, compound 4's estimate is 1.1-fold (0.04 log units) below it; the measured number falls inside the stated range.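

In this assay, for the compounds shown here, butyl in place of hydrogen on a saturated chain carbon, six bonds along the chain from an aromatic nitrogen and a double-bonded chain carbon, gives a number where compound 3 gives only a limit, and the step runs an at least 1.8-fold lower number from compound 3 to compound 4 (0.25 log units; that floor lies within the scatter) in the only readable step among the compounds carrying this chain. Going by these compounds alone, the earlier step to compound 3 cannot be read, so this is the first size available for any change here. That size is only a floor, because the step starts from a limit: the limit of > 50000 nM in this assay, at which 2 of the 4 values shown sit.

Going by these compounds, how far the true step runs therefore stays open. Within the data shown here, also open is whether a longer chain than the one on compound 4, or an amine at its end, would give a lower number in this assay.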